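Amide Variation at the Carbonyl Carbon in Breast Cancer Cells

The source may report more compounds than this note shows. Statements on the series, on what has been measured and on what is new or still open speak of the compounds shown alone.

Compound 1 `COc1ccc(/C=C/c2cc(OC)cc(OC)c2/C=C/C(=O)N2CCCCC2C)cc1` gives 4350 nM in a functional assay on MCF7 cells (Homo sapiens) for inhibition, read by MTT assay, with a stated time of 48 h (a lower number here means a stronger inhibitor, a higher number a weaker inhibitor), the top of the three numbers shown, although compound 3 `COc1ccc(/C=C/c2cc(OC)cc(OC)c2/C=C/C(=O)N2CCCC2)cc1` at 4200 nM and compound 2 `CCCCN(CCCC)C(=O)/C=C/c1c(/C=C/c2ccc(OC)cc2)cc(OC)cc1OC` at 3990 nM both sit within the scatter of it. Compound 4 `COc1ccc(/C=C/c2cc(OC)cc(OC)c2/C=C/C(=O)N2CCC(c3ccccc3)CC2)cc1` carries 4-phenylpiperidin-1-yl in place of 2-methylpiperidin-1-yl on a carbonyl carbon. Among the compounds with values here, the steps that bear on this exchange, a 1.1-fold lower number from compound 1 to compound 2 (0.04 log units; within the scatter) and a 1.0-fold lower number from compound 1 to compound 3 (0.02 log units; within the scatter), each replace the group on the carbonyl carbon and each stay within the scatter, as does a 1.1-fold higher number from compound 2 to compound 3 (0.02 log units; within the scatter). Within the data shown here, none of those steps brings in an aromatic ring, so the expectation rests only on the amide group having barely moved the number so far. Compound 4 is therefore expected at 4500 nM, with a range from 2000 nM to 10000 nM, which means an expected step of a 1.0-fold higher number from compound 1 to compound 4 (0.01 log units; within the scatter) not beyond the scatter.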

Compound 4, half-maximal inhibitory concentration: 4230 nM
Compound 4: middle estimate off by 1.1-fold (0.03 log units), on the high side, and the stated range covers the measured number.
By their numbers in this assay, from the lowest: compounds 2, 3, 4 and 1 (each within the scatter of the next).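

In this assay, 4-phenylpiperidin-1-yl brings an aromatic ring onto the carbonyl carbon, which none of the earlier amides did, yet all three new steps stay within the scatter (a 1.0-fold lower number from compound 1 to compound 4 (0.01 log units; within the scatter)), (a 1.0-fold higher number from compound 3 to compound 4 (0.00 log units; within the scatter)) and (a 1.1-fold higher number from compound 2 to compound 4 (0.03 log units; within the scatter)). Across these four compounds, the number therefore does not separate the open-chain dibutylamino group from the ring-bearing amides, with or without the added phenyl ring. Nothing shown explains why the number holds at this position.

Going by these compounds, whether a carboxylic acid or an amine in the amide group would move the number remains open. So does the effect of any change to the shared core.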